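A few compounds are considered here, and "the series" means these few. Any claim that something is new, unique, unknown or untested is made for them only; others in the source may bear on it.

Compound 1, `CCCCS(=O)(=O)NNC(=O)[C@@H](NC(=O)c1cccc(Cn2ccnc2)c1)[C@@H](C)CC`, gives only a limit in an assay on HEK293 cells for displacement of a labelled ligand from Type-2 angiotensin II receptor (Homo sapiens); a higher number here means a weaker inhibitor, a lower number a stronger inhibitor: > 100000 nM.
Compound 2, `CC[C@H](C)[C@H](NC(=O)c1cccc(Cn2ccnc2)c1)C(=O)NNS(=O)(=O)c1ccc(OC)cc1`, gives in this assay 9200 nM.

Compound 2 carries the only number shown in this assay; the other value is a limit. Among the compounds with values here, the one measured step, an at least 10-fold lower number from compound 1 to compound 2 (1.03 log units; beyond the scatter), is large and rests on (the limit of > 100000 nM in this assay, at which 1 of the 2 values shown sits), so its true size is not known. Compound 3, `CC[C@H](C)[C@H](NC(=O)c1cccc(Cn2ccnc2)c1)C(=O)NNC(=O)OC(C)(C)C`, is not yet measured in this assay; it differs from compound 2 in one place: tert-butoxycarbonyl in place of (4-methoxyphenyl)sulfonyl on an amine nitrogen. The step from compound 1 to compound 2 bears on this change: there a six-membered aromatic ring entered on a sulfonyl sulfur and the number fell sharply. In compound 3 the aromatic ring leaves again and a tert-butoxycarbonyl with no ring enters, so a weaker inhibitor is expected, with a step of a 5.4-fold higher number from compound 2 to compound 3 (0.74 log units; beyond the scatter). For compound 3 the estimate in this assay is 50000 nM, with a range from 12000 nM to 200000 nM.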

Compound 3, inhibition constant: > 100000 nM
Compound 3 was reported as a limit (the forecaster's own chance of this, stated with the estimate: 45%); middle value at least 2.0-fold (0.30 log units) from the limit.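

Replacing (4-methoxyphenyl)sulfonyl with tert-butoxycarbonyl on this amine nitrogen gives an at least 10-fold higher number from compound 2 to compound 3 (1.03 log units; beyond the scatter). Compound 1 showed this loss only when the sulfonyl stayed and butyl replaced the aromatic ring; compound 3 shows it with a different group with no ring, one that also lacks the sulfonyl. Among these three compounds, only compound 2, the one with a six-membered aromatic ring, gives a number in this assay, while the true size of the step to compound 3 is unknown and the step from compound 1 to compound 3 cannot be read: the limit of > 100000 nM in this assay, at which 2 of the 3 values shown sit.

As far as these compounds go, compound 3 changes the ring and the sulfonyl at once, so it remains open which of the two matters. A benzoyl group on this amine nitrogen, which keeps an aromatic ring without the sulfur, could separate them.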